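The source may hold more compounds than are shown below. What is called first, only, known or untested is meant among the compounds shown, and "the series" means these compounds.

In a functional assay on PANC-1 cells (Homo sapiens), read by microscopy, crystal violet staining and transwell migration, with a stated time of 18 h, in the presence of a further agent that is not named here (on this read-out higher numbers stand for weaker inhibition and lower numbers for stronger inhibition), compound 1 `CCc1nc(-c2ccc(OC)cc2)n(-c2cccc(C(=O)NCCCCc3ccccc3)c2)n1` gives 140 nM. Compound 2 `COc1ccc(-c2nc(C(C)C)nn2-c2cccc(C(=O)NCCCCc3ccccc3)c2)cc1` gives only a limit of the assay, > 20000 nM. The step between them, an at least 140-fold higher number from compound 1 to compound 2 (2.15 log units; beyond the scatter), is large and beyond the scatter, and it comes from methyl in place of hydrogen on a saturated chain carbon. Compound 3 `COc1ccc(-c2nc(C3CC3)nn2-c2cccc(C(=O)NCCCCc3ccccc3)c2)cc1` changes the same substituent of compound 2: cyclopropyl in place of isopropyl on an aromatic carbon. Within the data shown here, only the step to compound 2, an at least 140-fold higher number from compound 1 to compound 2 (2.15 log units; beyond the scatter), bears on this change, and it shows that inhibition here can be lost sharply at this place. Some recovery is therefore expected, though probably not all the way back to the value of compound 1, 140 nM. The expected change is an at least 6.6-fold lower number from compound 2 to compound 3 (0.82 log units; beyond the scatter) in this assay, towards stronger inhibition. Compound 3 is estimated at 3000 nM, with an expected range of 400 nM to 20000 nM.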

Compound 3, half-maximal inhibitory concentration: 7680 nM
Estimate against measurement, compound 3: 2.6-fold (0.41 log units) below; measured number inside the range.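

In this assay, this position turns out not to be closed to every group of three carbons: cyclopropyl in place of isopropyl on the aromatic carbon brings back measurable inhibition (an at least 2.6-fold lower number from compound 2 to compound 3 (0.41 log units; beyond the scatter)). On these data alone, compound 2 stands at a limit and not at a number, so the full size of that step stays unknown: the limit of > 20000 nM in this assay, at which 1 of the 3 values shown sits. The recovery is only partial, and the ring does not stand in for ethyl at this carbon (a 55-fold higher number from compound 1 to compound 3 (1.74 log units; beyond the scatter)), so the gain from cyclopropyl does not bring compound 3 back to compound 1.

As far as these compounds go, whether methyl or a straight propyl chain at this carbon would match ethyl or fall away remains open. So does the effect of an amine or a methoxy group here, where only carbon groups are shown.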